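The compounds below may be only part of what the source reports. "The series", "measured", "known", "first", "only" and "open" are said of these compounds alone.

Measured compounds in this series:

compound 1 `CCOc1ccc2nc(C(=O)Nc3c(F)cc(-c4cccc(F)c4)cc3F)c(C)c(O)c2c1` — 1.03%
compound 2 `Cc1c(C(=O)Nc2c(F)cc(-c3cccc(F)c3)cc2F)nc2ccc(OC(F)(F)F)cc2c1O` — 17.2%
compound 3 `Cc1c(C(=O)Nc2c(F)cc(-c3cccc(F)c3)cc2F)nc2ccc(C(F)(F)F)cc2c1O` — 15.3%

In a functional assay on Hep 3B2 cells (Homo sapiens) for antiproliferative activity, read by MTT assay, with a stated time of 24 h, tested at 1.23 ug/mL (a higher number here means a stronger effect of the compound at the concentration tested, a lower number a weaker effect), compound 1 stands lowest of the three numbers. The steps of a number 16.2 percentage points higher from compound 1 to compound 2 (beyond the scatter) and a number 14.3 percentage points higher from compound 1 to compound 3 (beyond the scatter) both exceed the scatter, whereas a number 1.9 percentage points lower from compound 2 to compound 3 (within the scatter) does not. Compound 4 `CCOc1ccc2nc(C(=O)Nc3c(F)cc(-c4cccc(F)c4)cc3F)c(C)c(C(=O)O)c2c1` is not yet measured. It differs from compound 1 in one place: carboxy in place of hydroxy on an aromatic carbon. Among the measured compounds shown here, none of the measured steps touches this position; all three measured compounds keep the hydroxy group, and the steps recorded concern only the ethoxy group, trifluoromethoxy and trifluoromethyl. For the measured compounds named here, there is therefore no measured step that bears on the change from compound 1 to compound 4, and the expectation rests on compound 1 alone. With nothing to point in either direction, no step beyond the scatter is expected in this assay, so the estimated step is a number 3 percentage points higher from compound 1 to compound 4 (within the scatter). Compound 4 is thus estimated at 4% in this assay, with a range from -8% to 18% reflecting the absence of any directly comparable step.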

Compound 4, a percentage reported as inhibition, at one concentration (the size of the read-out at that concentration, not a potency): 17.9%
Estimate against measurement, compound 4: 13.9 percentage points below; the range from low to high includes it.
By their numbers in this assay, from the lowest: compound 1; then compounds 3, 2 and 4 (each within the scatter of the next).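

In this assay, the position opposite the ring nitrogen, held by hydroxy in compounds 1, 2 and 3, responds to substitution: carboxy in place of hydroxy gives a number 16.9 percentage points higher from compound 1 to compound 4 (beyond the scatter). This is the first measured step at this position, so the read-out is now shown to change here as well as at the group that carries ethoxy, trifluoromethoxy or trifluoromethyl. No measurement available here accounts for the step.

Carboxy appears only with ethoxy, so it remains open whether the step would carry over to the trifluoromethoxy or trifluoromethyl compounds. Also open, on these data alone, is how a methyl ester, a primary amide or an amine at this position would compare with carboxy and hydroxy, and whether any such change would hold at other concentrations.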